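Working notes: from hydroxymethyl to 1-hydroxy-1-methylethyl

A few compounds are considered here, and "the series" means these few. Any claim that something is new, unique, unknown or untested is made for them only; others in the source may bear on it.

Measured so far in a physicochemical assay for acid dissociation:
compound 1 `CC(=O)NCc1cccc(Cn2nc(NS(=O)(=O)c3ccc(Cl)s3)c3c(O)cccc32)c1` gives 6.12
compound 2 `CC(=O)NCc1cccc(Cn2nc(NS(=O)(=O)c3ccc(Cl)s3)c3c(CO)cccc32)c1` gives 5.66

Of the two numbers, compound 2 has the lower (5.66), and compound 1 stands higher (6.12). The next structure is compound 3 `CC(=O)NCc1cccc(Cn2nc(NS(=O)(=O)c3ccc(Cl)s3)c3c(C(C)(C)O)cccc32)c1`, which carries 1-hydroxy-1-methylethyl in place of the hydroxymethyl of compound 2, on an aromatic carbon, ortho to a fused ring and meta to a fused ring (1-hydroxy-1-methylethyl in place of hydroxymethyl on an aromatic carbon). Among the measured compounds shown here, one measured step bears on this: a number 0.46 log units lower from compound 1 to compound 2 (beyond the scatter), with hydroxymethyl in place of hydroxy on an aromatic carbon. For the measured compounds named here, no measured step starts from hydroxymethyl, so this is a thin guide. A smaller step than that one is expected in this assay, with nothing beyond the scatter and no firm direction. The step expected is small (a number 0.04 log units higher from compound 2 to compound 3 (within the scatter)). Compound 3 is estimated at 5.7 with an expected range of 5.3 to 6.1 for the measurement.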

Compound 3, acid dissociation constant: 5.46
For compound 3 the middle estimate is 0.24 log units above the measured one, and the stated range covers the measured number.
By their numbers in this assay, from the lowest: compounds 3 and 2 (each within the scatter of the next); then compound 1.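

At this aromatic carbon, ortho to a fused ring and meta to a fused ring, replacing hydroxymethyl with 1-hydroxy-1-methylethyl gives a number 0.20 log units lower from compound 2 to compound 3 (within the scatter) in this assay, so the two groups cannot be told apart in this assay, even with the heavy-atom count of the group rising from 2 to 4. The shift seen on leaving hydroxy now appears with a second group: going to 1-hydroxy-1-methylethyl gives a number 0.66 log units lower from compound 1 to compound 3 (beyond the scatter), so among these three compounds, both groups with the hydroxyl on a carbon substituent give numbers beyond the scatter from the hydroxy compound, with no compound going against this. No measurement in hand accounts for either step.

The compounds shown leave open whether a group with no hydroxyl at this place, such as methyl, methoxy or an amine, would read with compound 2 and compound 3 or with compound 1. A carboxylic acid or a longer chain ending in hydroxy at the same carbon also remains to be placed on this scale.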